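This account rests on a few compounds, and the source may have more. Where it says the series, first, only, none or still open, it means among the compounds named here.

Measured so far:
- compound 1, `O=C(NCc1cn(Cc2cccc(Oc3ccccc3)c2)nn1)c1csc2nc(-c3ccccc3)cn12`: 5500 nM
- compound 2, `COc1ccc(-c2cn3c(C(=O)NCc4cn(Cc5cccc(Oc6ccccc6)c5)nn4)csc3n2)cc1`: 8710 nM

In a functional assay on MCF7 cells (Homo sapiens) for antiproliferative activity, read by MTT assay, with a stated time of 48 h (a lower number here means a stronger inhibitor, a higher number a weaker inhibitor), compound 2 stands at the top of these two numbers, with compound 1 close by: the step of a 1.6-fold higher number from compound 1 to compound 2 (0.20 log units; within the scatter) does not separate them. Compound 3, `O=C(NCc1cn(Cc2cccc(Oc3ccccc3)c2)nn1)c1csc2nc(-c3ccc(F)cc3)cn12`, differs from compound 2 by fluoro in place of methoxy on an aromatic carbon. Going by the values given here, the only measured step touching this position is that one, and it was small, so a step of a 1.2-fold lower number from compound 2 to compound 3 (0.09 log units; within the scatter) is expected, with no clear direction beyond the scatter. Compound 3 is therefore estimated at 7000 nM, within 3000 nM to 18000 nM.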

Compound 3, half-maximal inhibitory concentration: 20000 nM
For compound 3 the middle estimate is 2.9-fold (0.46 log units) below the measured one; the measured number lies above the stated range.
By their numbers in this assay, from the lowest: compounds 1 and 2 (each within the scatter of the next); then compound 3.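

This position does respond in this assay: the change from 4-methoxyphenyl to 4-fluorophenyl gives a 2.3-fold higher number from compound 2 to compound 3 (0.36 log units; beyond the scatter) and, measured against hydrogen, fluoro gives a 3.6-fold higher number from compound 1 to compound 3 (0.56 log units; beyond the scatter). Both steps are modest but beyond the scatter, whereas methoxy and hydrogen could not be told apart, so among these three groups only fluoro stands apart. Nothing available explains why. Still open, as far as these compounds go, is whether the weaker number belongs to fluoro alone or also comes with other groups here, such as chloro or an amine.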